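The compounds below may be only part of what the source reports. "The series", "measured", "known", "first", "only" and "open" are said of these compounds alone.

Compound 1 `CS(=O)(=O)c1cnc(C(=O)CCc2ccc(-c3ccccc3)cc2)o1` carries a methylsulfonyl on its five-membered aromatic core. In an assay for inhibition of Fatty-acid amide hydrolase 1 (Rattus norvegicus) (a higher number here means a weaker inhibitor, a lower number a stronger inhibitor), compound 1 gives 1.2 nM, the lowest of the three numbers gathered so far. Compound 3 `COC(=O)c1ccc(-c2cnc(C(=O)CCc3ccc(COc4ccccc4)cc3)o2)nc1` comes nearest to it, giving 3.5 nM in this assay, a gap that lies beyond the scatter. Compound 2 `O=C(O)c1ccc(-c2cnc(CCCc3ccc(-c4ccccc4)cc3)o2)nc1` stands far off, giving 20000 nM in this assay. Among these three, no pair differs in only one place, so no single step can be read directly from the measured compounds; what can be seen is that compound 1 and compound 3, which both keep the carbonyl, give low numbers, while compound 2, which lacks it, gives a very high one.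

Compound 4 `CSc1cnc(C(=O)CCc2ccc(-c3ccccc3)cc2)o1` differs from compound 1 in one place: methylsulfanyl in place of methylsulfonyl on an aromatic carbon. For the measured compounds named here, with no measured step to lean on, the expectation rests on the change alone; the step of an 8.3-fold higher number from compound 1 to compound 4 (0.92 log units; beyond the scatter) is expected to be a weakening of modest size, beyond the scatter. The estimate for compound 4 in this assay is 10 nM, within a range from 3 nM to 40 nM.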

Compound 4, inhibition constant: 3 nM
Compound 4: the middle estimate sits 3.3-fold (0.52 log units) above what was measured, and the stated range covers the measured number.
By their numbers in this assay, from the lowest: compound 1; then compounds 4 and 3 (each within the scatter of the next); then compound 2.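

For the compounds shown here, this is the first step that can be read directly, and it falls on the aromatic carbon next to the ring oxygen of the shared core. In this assay, methylsulfanyl in place of methylsulfonyl gives a 2.5-fold higher number from compound 1 to compound 4 (0.40 log units; beyond the scatter), a modest weakening beyond the scatter, and compound 4 still gives 3 nM, so a low number at this place does not require the methylsulfonyl. Nothing measured here accounts for the size of this step.

Going by these compounds, with a single change read at this position, it remains open how a different group there, such as an amine, a nitrile or a longer alkyl chain, would compare with these two. On these data alone, it also remains open whether the same exchange would give a step of similar size on a compound with a different chain on the carbonyl side.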